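Isopropyl for trifluoromethyl on the aryl tail of compound 1

This account rests on a few compounds, and the source may have more. Where it says the series, first, only, none or still open, it means among the compounds named here.

For the measured compounds named here, compound 1 `CCn1nc(C)c2c1CCN([C@@H](C(=O)NC)c1ccccc1)[C@H]2CCc1ccc(C(F)(F)F)cc1` is one of three compounds measured in a functional assay on CHO cells for antagonist activity at Orexin/Hypocretin receptor type 1 (Homo sapiens), read by FLIPR and calcium flux; on this read-out lower numbers stand for stronger inhibition and higher numbers for weaker inhibition. Compound 1 gives 128 nM, the second highest of the three numbers; compound 2 `CCn1nc(C)c2c1CCN(C(C(=O)NC)c1ccccc1)C2CCc1ccc(C)cc1` gives 108 nM and compound 3 `CCn1nc(C)c2c1CCN(C(C(=O)NC)c1ccccc1)C2CCc1cccc(C)c1` gives 180 nM. Going by the values given here, all three numbers lie within the scatter of one another, and the single measured step, a 1.7-fold higher number from compound 2 to compound 3 (0.22 log units; within the scatter), also stays inside it. Compound 4 `CCn1nc(C)c2c1CCN([C@@H](C(=O)NC)c1ccccc1)[C@H]2CCc1ccc(C(C)C)cc1` differs from compound 1 in one place: isopropyl in place of trifluoromethyl on an aromatic carbon. Among the compounds with values here, no measured pair shows this exact change. Compound 2 carries 4-methylphenyl where compound 1 carries 4-(trifluoromethyl)phenyl, and their two values show no difference beyond the scatter; the step from compound 2 to compound 3 moves the methyl to another position on the ring and likewise stays small. On that basis the expected step is a 1.0-fold higher number from compound 1 to compound 4 (0.01 log units; within the scatter), with no direction beyond the scatter. Compound 4 is therefore estimated at 130 nM, within a range of 60 nM to 280 nM.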

Compound 4, half-maximal inhibitory concentration: 161 nM
Compound 4: middle estimate off by 1.2-fold (0.09 log units), on the low side; the range from low to high includes it.
By their numbers in this assay, from the lowest: compounds 2, 1, 4 and 3 (each within the scatter of the next).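

In this assay the exchange of trifluoromethyl for isopropyl on the aromatic carbon para to a large group gives a 1.3-fold higher number from compound 1 to compound 4 (0.10 log units; within the scatter). This is the first step shown in which one group at this place is replaced by another, and it does not separate the two groups on this read-out. Together with the methyl of compound 2, the four values so far form a flat picture across the small carbon-based groups on this ring, but no measurement of any property of these groups accompanies them.

As far as these compounds go, it remains open whether a carboxylic acid, an amine or a longer chain at this place would leave the number within the same scatter. From the compounds shown here alone, it also remains open whether the exchange of trifluoromethyl for isopropyl would read the same on a different core.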